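Amino substitution on two nucleoside cores

This account rests on a few compounds, and the source may have more. Where it says the series, first, only, none or still open, it means among the compounds named here.

Compound 1 `COc1ncnc2c1c(-c1ccoc1)cn2[C@@H]1O[C@H](CO)[C@@H](O)[C@H]1O` is one of two measured parents. In a functional assay on HCT-116 cells (Homo sapiens), read by MTT assay, with a stated time of 72 h (a lower number here means a stronger inhibitor, a higher number a weaker inhibitor), compound 1 gives 110 nM. Compound 2 `COc1nc(N)nc2c1c(-c1ccoc1)cn2[C@@H]1O[C@H](CO)[C@@H](O)[C@H]1O` carries amino in place of hydrogen on an aromatic carbon. For compound 2 this assay reports only a limit, > 20000 nM. That change gave an at least 180-fold higher number from compound 1 to compound 2 (2.25 log units; beyond the scatter). Compound 3 `O=c1[nH]cnc2c1c(-c1ccccc1)cn2[C@@H]1O[C@H](CO)[C@@H](O)[C@H]1O` rests on a different core; the difference between the two cores is not broken down here. For compound 3 this assay reports only a limit, > 100000 nM. Compound 4 `Nc1nc2c(c(-c3ccccc3)cn2[C@@H]2O[C@H](CO)[C@@H](O)[C@H]2O)c(=O)[nH]1` is not yet measured and carries amino in place of hydrogen on an aromatic carbon. This is the same kind of change as in compound 2, the place differing in that it is meta to a group of 1 heavy atom rather than meta to a methoxy group (2 heavy atoms). Compound 4 is expected to show a step that the limit leaves unreadable from compound 3 to compound 4, because compound 3 already sits at the limit of > 100000 nM in this assay, at which 1 of the 3 values shown sits, and the same change gave an at least 180-fold higher number from compound 1 to compound 2 (2.25 log units; beyond the scatter). Compound 4 is therefore estimated at 300000 nM, most likely reported only as a limit.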

Compound 4, half-maximal inhibitory concentration: > 20000 nM
Compound 4 ended at the assay's limit; the forecaster's own chance of this, stated with the estimate: 95%; the middle value does not contradict the limit.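

In this assay, compound 3 and compound 4 are each reported only as a limit, so no step can be read between them. As far as these compounds go, whether the amino group weakens activity on the core of compound 3 remains open.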